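The compounds below may be only part of what the source reports. "The series", "measured", "known", "first", "only" and "open" are said of these compounds alone.

Of the compounds shown here, two from this series have been tested in a functional assay on SMMC-7721 cells (Homo sapiens) for cytotoxicity, read by MTT assay, with a stated time of 72 h; on this read-out lower numbers stand for stronger inhibition and higher numbers for weaker inhibition. Compound 1 `CCC(C)=C1C(=O)N(c2ccc(Cl)cc2)N(c2ccc(Cl)cc2)C1=O` gives 49200 nM in this assay. Among the compounds with values here, compound 2 `COc1cc(C=C2C(=O)N(c3ccc(Cl)cc3)N(c3ccc(Cl)cc3)C2=O)ccc1O` gives 64900 nM in this assay, the highest of the two numbers so far; compound 1 is the nearest, and the gap between the two lies within the usual scatter, so neither can be ranked against the other.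

Compound 3 `O=C1C(=Cc2c[nH]c3ccccc23)C(=O)N(c2ccc(Cl)cc2)N1c1ccc(Cl)cc1` has not yet been measured. It differs from compound 2 in one place: 1H-indol-3-yl in place of 4-hydroxy-3-methoxyphenyl on a double-bonded chain carbon bound to a double-bonded ring carbon. The two measured compounds share the same core, and their numbers sit close together despite unrelated groups on the double-bonded chain carbon, which gives little ground for expecting a large shift in either direction from a further swap at that position.

Compound 3 is therefore expected to land near the measured pair, with a step from compound 2 estimated at a 1.3-fold lower number from compound 2 to compound 3 (0.11 log units; within the scatter), which is no more than the scatter allows. The estimate for compound 3 in this assay is 50000 nM, within a range from 15000 nM to 160000 nM.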

Compound 3, half-maximal inhibitory concentration: 19600 nM
Beside the measured number, compound 3's estimate is 2.6-fold (0.41 log units) above it, within the range that was stated.
By their numbers in this assay, from the lowest: compound 3; then compounds 1 and 2 (each within the scatter of the next).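

In this assay, putting 1H-indol-3-yl in place of 4-hydroxy-3-methoxyphenyl on a double-bonded chain carbon bound to a double-bonded ring carbon gives a 3.3-fold lower number from compound 2 to compound 3 (0.52 log units; beyond the scatter), a modest step but one beyond the scatter, so the group at this position can move the number, which the close values of the earlier pair had not shown. The two groups are equal in heavy atoms and in hydrogen-bond donors, and they differ in hydrogen-bond acceptors and in the five-membered aromatic ring that enters, so the step comes with a change of ring type and acceptor count rather than of size as counted in heavy atoms. Nothing available here shows which of these differences lies behind the step.

Going by these compounds, it remains open whether a plain phenyl, a pyridyl or a thienyl group at this position would give a number like that of compound 3, and whether the amide hydrogen of the shared core's neighbours matters less than the indole ring hydrogen, which a methyl group on the indole nitrogen would test. Also open, on these data alone, is how an amine or a carboxylic acid on the indole ring would shift the number.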